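Swapping 4-fluorophenyl for thiophen-2-yl on the shared core

The compounds below may be only part of what the source reports. "The series", "measured", "known", "first", "only" and "open" are said of these compounds alone.

Values in a functional assay on RAW264.7 cells (Mus musculus) for inhibition, read by Griess assay, with a stated time of 24 h; on this read-out higher numbers stand for weaker inhibition and lower numbers for stronger inhibition:
- compound 1 `CC(=O)S[C@]12CC[C@H](O)[C@H]1C(=O)NC2=O`: 833000 nM
- compound 2 `O=C(S[C@]12CC[C@H](O)[C@H]1C(=O)NC2=O)c1ccccc1Cl`: 178000 nM
- compound 3 `O=C(S[C@]12CC[C@H](O)[C@H]1C(=O)NC2=O)c1ccc(F)cc1`: 318000 nM

Compound 3 cannot be told apart from compound 2, as a 1.8-fold higher number from compound 2 to compound 3 (0.25 log units; within the scatter) shows, while a 2.6-fold lower number from compound 1 to compound 3 (0.42 log units; beyond the scatter) separates it from compound 1. Compound 4 `O=C(S[C@]12CC[C@H](O)[C@H]1C(=O)NC2=O)c1cccs1` carries thiophen-2-yl in place of 4-fluorophenyl on a carbonyl carbon. Within the data shown here, the closest precedent is the exchange of one aromatic group for another in a 1.8-fold higher number from compound 2 to compound 3 (0.25 log units; within the scatter). Larger steps, a 4.7-fold lower number from compound 1 to compound 2 (0.67 log units; beyond the scatter) and a 2.6-fold lower number from compound 1 to compound 3 (0.42 log units; beyond the scatter), came only from replacing methyl, which this change does not do. No step beyond the scatter is therefore expected in this assay. The expected change is a 1.3-fold lower number from compound 3 to compound 4 (0.10 log units; within the scatter). The estimate for compound 4 is 250000 nM, within an expected range of 110000 nM to 550000 nM.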

Compound 4, half-maximal inhibitory concentration: 36600 nM
Compound 4: middle estimate off by 6.8-fold (0.83 log units), on the high side, outside the stated range (below it).
By their numbers in this assay, from the lowest: compound 4; then compounds 2 and 3 (each within the scatter of the next); then compound 1.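

Exchanging one aromatic group for another on this carbonyl carbon can clearly matter: in this assay, thiophen-2-yl gives an 8.7-fold lower number from compound 3 to compound 4 (0.94 log units; beyond the scatter) and a 4.9-fold lower number from compound 2 to compound 4 (0.69 log units; beyond the scatter), whereas the earlier aromatic exchange stayed within the scatter. Compared with methyl, it gives a 23-fold lower number from compound 1 to compound 4 (1.36 log units; beyond the scatter), so the identity of the aromatic group counts, not just its presence. Nothing measured here explains this difference.

Still open, going by these compounds, is whether furan-2-yl or thiophen-3-yl on the same carbonyl carbon would match thiophen-2-yl.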